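A few compounds are considered here, and "the series" means these few. Any claim that something is new, unique, unknown or untested is made for them only; others in the source may bear on it.

Series values in a functional assay on HCT-116 cells (Homo sapiens) for inhibition, read by sulforhodamine B assay, with a stated time of 48 h, tested at 50 uM; on this read-out higher numbers stand for more inhibition of growth at the one concentration tested and lower numbers for less inhibition of growth
- compound 1 `COc1cc(/C=C/C(=O)/C=C/c2ccco2)ccc1OCc1cn(CCCOc2cc(=O)oc3ccccc23)nn1` gives 51%
- compound 2 `COc1cccc(/C=C/C(=O)/C=C/c2ccc(OCc3cn(CCCOc4cc(=O)oc5ccccc45)nn3)c(OC)c2)c1` gives 55%
- compound 3 `COc1cc(/C=C/C(=O)/C=C/c2ccccc2)ccc1OCc1cn(CCOc2cc(=O)oc3ccccc23)nn1` gives 56%

Among the compounds with values here, compound 2 at 55% lies within the scatter of both other compounds, so the numbers so far do not separate it from them.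

Compound 4 `COc1cc(/C=C/C(=O)/C=C/c2ccccc2)ccc1OCc1cn(CCCOc2cc(=O)oc3ccccc23)nn1` differs from compound 2 in one place (hydrogen in place of methoxy on an aromatic carbon), with hydrogen in place of methoxy on an aromatic carbon, so 3-methoxyphenyl becomes phenyl.

Within the data shown here, one measured step touches this same end of the molecule. That step, a number 4 percentage points higher from compound 1 to compound 2 (within the scatter), exchanges furan-2-yl for 3-methoxyphenyl and gives no separation. Although its chain differs from that of compound 4, compound 3 also carries the phenyl end and gives 56%.

No step beyond the scatter is therefore expected in this assay, and no direction can be assigned. The estimated change is no change at the digits printed from compound 2 to compound 4 (within the scatter). For compound 4 the expected value is 55%, with an estimated range of 45% to 65%.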

Compound 4, percent growth inhibition at one concentration: 45%
Compound 4: the middle estimate sits 10 percentage points above what was measured; measured number inside the range.
By their numbers in this assay, from the lowest: compounds 4, 1, 2 and 3 (each within the scatter of the next, the first and the last beyond it).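

In this assay hydrogen in place of methoxy on the aromatic carbon gives a number 10 percentage points lower from compound 2 to compound 4 (within the scatter) and phenyl in place of furan-2-yl gives a number 6 percentage points lower from compound 1 to compound 4 (within the scatter) on the same chain. With these steps, furan-2-yl, 3-methoxyphenyl and phenyl have all been compared at this end of the molecule, and this assay separates none of the three from the others. No measurement available here bears on the reason for these numbers.

Going by these compounds, whether an amine or a carboxylic acid at this aromatic carbon would give a step beyond the scatter stays open. Compound 3 at 56% and compound 4 at 45% lie beyond the scatter of each other and differ in their chain, but this single pair does not show how a longer chain would read.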